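Methyl on the phenol oxygen, read across two cores

The source may hold more compounds than are shown below. What is called first, only, known or untested is meant among the compounds shown, and "the series" means these compounds.

Compound 1 `N=C(NCc1ccc(O)cc1)[C@@H]1CCC(=O)N1Cc1ccc(F)cc1` gives 42% in a functional assay on SH-SY5Y cells (Homo sapiens) for cytotoxicity, read by MTT assay, with stated times of 8 h, 30 min and 12 h, tested at 0.5 uM; on this read-out lower numbers stand for a weaker effect and higher numbers for a stronger effect at the one concentration tested. Compound 2 `COc1ccc(CNC(=N)[C@@H]2CCC(=O)N2Cc2ccc(F)cc2)cc1` carries the change (methyl in place of hydrogen on an oxygen on an aromatic ring); in this assay compound 2 gives 36.7%, a step of a number 5.3 percentage points lower from compound 1 to compound 2 (within the scatter). Compound 3 `Cc1ccc(CN2C(=O)CC[C@H]2C(=N)NCc2ccc(O)cc2)cc1` differs from compound 1 in its core by methyl in place of fluoro on an aromatic carbon; in this assay compound 3 gives 21.9%, a step of a number 20.1 percentage points lower from compound 1 to compound 3 (beyond the scatter), and it stands lowest of the three. Compound 4 `COc1ccc(CNC(=N)[C@@H]2CCC(=O)N2Cc2ccc(C)cc2)cc1` is not yet measured and differs from compound 3 by methyl in place of hydrogen on an oxygen on an aromatic ring, the same change that turns compound 1 into compound 2, made twice in all among these compounds and described in the same words at the same kind of place. For compound 4 the expected step is a number 5.3 percentage points lower from compound 3 to compound 4 (within the scatter), resting on the earlier step of a number 5.3 percentage points lower from compound 1 to compound 2 (within the scatter) that stayed within the scatter. Compound 4 is estimated at 16.6%, between 6% and 28%.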

Compound 4, a percentage reported as activity, at one concentration (the size of the read-out at that concentration, not a potency): 21.9%
For compound 4 the middle estimate is 5.3 percentage points below the measured one; the measured number falls inside the stated range.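

In this assay the change from hydroxy to methoxy on the 4-hydroxyphenyl group gives no change at the digits printed from compound 3 to compound 4 (within the scatter), and it reads the same on both cores: the same change on two cores in this assay, a number 5.3 percentage points lower (within the scatter) from compound 1 to compound 2 and no change at the digits printed (within the scatter) from compound 3 to compound 4, 5.3 percentage points apart, within the scatter of two such steps.
The change to methyl in place of fluoro, which gives a number 14.8 percentage points lower from compound 2 to compound 4 (beyond the scatter), also carries over between the two pairs: the same change on two cores in this assay, a number 20.1 percentage points lower (beyond the scatter) from compound 1 to compound 3 and a number 14.8 percentage points lower (beyond the scatter) from compound 2 to compound 4, 5.3 percentage points apart, within the scatter of two such steps.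
This shows that both changes carried over within this set of four compounds, but the methoxy step stays within the scatter on both cores, so it shows no effect of the methyl itself, and two pairs at one concentration say nothing about potency or about other cores.

Still open, going by these compounds, is whether a longer chain on that oxygen would read the same way. The same holds for an amine or a carboxylic acid in place of the hydroxy.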